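A nitro for acetamido on a weakly active analogue

The source may hold more compounds than are shown below. What is called first, only, known or untested is meant among the compounds shown, and "the series" means these compounds.

Compound 3 `CC(=O)Nc1ccc(-n2nncc2CN2C(=O)C3(C(C#N)=C(N)Oc4c(N)cc5nc6ccccc6nc5c43)c3ccccc32)cc1` stands at the edge of the measured range: in a functional assay on HCT-116 cells (Homo sapiens) for antiproliferative activity, read by MTT assay, with a stated time of 48 h (a lower number here means a stronger inhibitor, a higher number a weaker inhibitor), compound 3 returns > 50000 nM, which is a limit rather than a number. Compound 1 `CCc1ccccc1-n1nncc1CN1C(=O)C2(C(C#N)=C(N)Oc3c(N)cc4nc5ccccc5nc4c32)c2ccccc21` gives 10300 nM in this assay. Compound 2 `N#CC1=C(N)Oc2c(N)cc3nc4ccccc4nc3c2C12C(=O)N(Cc1cnnn1-c1ccccc1Cl)c1ccccc12` likewise rests at a limit, with > 50000 nM. The steps reaching compound 3 are an at least 4.8-fold higher number from compound 1 to compound 3 (0.68 log units; beyond the scatter) and a step that the two limits leave unreadable from compound 2 to compound 3, while an at least 4.8-fold higher number from compound 1 to compound 2 (0.68 log units; beyond the scatter) shows how quickly this series runs into (the limit of > 50000 nM in this assay, at which 2 of the 3 values shown sit). Compound 4 `N#CC1=C(N)Oc2c(N)cc3nc4ccccc4nc3c2C12C(=O)N(Cc1cnnn1-c1ccc([N+](=O)[O-])cc1)c1ccccc12` differs from compound 3 by nitro in place of acetamido on an aromatic carbon. Among the compounds with values here, no measured step covers this change, and compound 3 already sits at the limit, so compound 4 is expected to show no step beyond the scatter, an expected at least 1.2-fold lower number from compound 3 to compound 4 (0.09 log units; that floor lies within the scatter). Compound 4 is therefore estimated at 40000 nM, between 10000 nM and 60000 nM.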

Compound 4, half-maximal inhibitory concentration: > 50000 nM
Compound 4: no number, only a limit; the forecaster's own chance of this, stated with the estimate: 60%; at least 1.2-fold (0.09 log units) between middle value and limit.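

With nitro in place of acetamido, compound 4 rests at a limit, as compound 3 does, so the steps among compound 2, compound 3 and compound 4 cannot be read. The 4-nitrophenyl group, set against the 2-ethylphenyl group of compound 1, gives an at least 4.8-fold higher number from compound 1 to compound 4 (0.68 log units; beyond the scatter). Only compound 1 now carries a number rather than a limit in this assay, and the other compounds gather at one edge: the limit of > 50000 nM in this assay, at which 3 of the 4 values shown sit.

The limits leave open whether nitro and acetamido differ at all at this position. On these data alone, whether an amine or a carboxylic acid there would return a number also remains open.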